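The compounds below may be only part of what the source reports. "The series", "measured", "known", "first", "only" and "open" are said of these compounds alone.

Measured so far:
compound 1, `O=C1O/C(=C\Cn2ccc(=O)[nH]c2=O)C(OCc2ccccc2)=C1OCc1ccccc1`, 17700 nM in a functional assay on FM3A cells (Mus musculus) for inhibition; on this read-out lower numbers stand for stronger inhibition and higher numbers for weaker inhibition
compound 2, `O=C1O/C(=C\Cn2cc(Cl)c(=O)[nH]c2=O)C(OCc2ccccc2)=C1OCc1ccccc1`, 16900 nM

Compound 2 holds the lower of the two numbers, yet the step between them is a 1.0-fold lower number from compound 1 to compound 2 (0.02 log units; within the scatter), so the two stand level. Compound 3 is `O=C1O/C(=C\Cn2cc(Br)c(=O)[nH]c2=O)C(OCc2ccccc2)=C1OCc1ccccc1`, and the change is bromo in place of chloro on an aromatic carbon. Within the data shown here, the only step that bears on it, the one of a 1.0-fold lower number from compound 1 to compound 2 (0.02 log units; within the scatter), swaps one group of one heavy atom for hydrogen at the same carbon and moved nothing. Exchanging one halogen for another is expected to move nothing either; the expected step is a 1.1-fold lower number from compound 2 to compound 3 (0.02 log units; within the scatter). Compound 3 is estimated at 16000 nM, between 8000 nM and 32000 nM.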

Compound 3, half-maximal inhibitory concentration: 17100 nM
Estimate against measurement, compound 3: 1.1-fold (0.03 log units) below; the range from low to high includes it.
By their numbers in this assay, from the lowest: compounds 2, 3 and 1 (each within the scatter of the next).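

In this assay, the step for bromo in place of chloro is a 1.0-fold higher number from compound 2 to compound 3 (0.01 log units; within the scatter) and the step for bromo in place of hydrogen is a 1.0-fold lower number from compound 1 to compound 3 (0.01 log units; within the scatter), so the larger halogen leaves this position as flat as chloro did. Hydrogen, chloro and bromo on this aromatic carbon now stand level, which extends the flat reading from one halogen to two. Nothing available explains this flat reading.

Still open, on these data alone, is whether a non-halogen group on this carbon, such as an amine, a carboxylic acid or a longer alkyl chain, would depart from this level.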